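Replacing hydroxy with trifluoromethyl on compound 3

The source may hold more compounds than are shown below. What is called first, only, known or untested is meant among the compounds shown, and "the series" means these compounds.

In a functional assay on MDA-MB-231 cells (Homo sapiens) for inhibition, read by MTT assay, with a stated time of 48 h (a higher number here means a weaker inhibitor of growth, a lower number a stronger inhibitor of growth), compound 1 (`CC(C)(C)c1ccc(Nc2ncnc3ccc(NC(=S)NCc4ccccc4)cc23)cc1`) gives 8700 nM. Compound 2 (`Oc1cccc(Nc2ncnc3ccc(NC(=S)NCc4ccccc4)cc23)c1`) gives > 30000 nM, which is a limit of the assay and not a number. Compound 3 (`Oc1ccc(NC(=S)Nc2ccc3ncnc(Nc4cccc(Br)c4)c3c2)cc1`) gives 17300 nM, which lies within the usual scatter of the value for compound 1.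

The unmeasured compound 4 (`FC(F)(F)c1ccc(NC(=S)Nc2ccc3ncnc(Nc4cccc(Br)c4)c3c2)cc1`) differs from compound 3 in one place: trifluoromethyl in place of hydroxy on an aromatic carbon. This puts trifluoromethyl in place of hydroxy on an aromatic carbon, turning 4-hydroxyphenyl into 4-(trifluoromethyl)phenyl.

For the measured compounds named here, only one measured step bears on this change, and only loosely: an at least 3.4-fold higher number from compound 1 to compound 2 (0.53 log units; beyond the scatter). There, a hydroxy-carrying group arrives at a different place in the molecule and the number rises. Read in reverse, that step suggests that losing hydroxy may bring the number down, so a modest drop is expected in this assay, though a single step is thin support. The expected change is a 1.7-fold lower number from compound 3 to compound 4 (0.24 log units; within the scatter). For compound 4 the estimated value is 10000 nM, with an expected range of 4000 nM to 25000 nM.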

Compound 4, concentration for 50% growth inhibition: 12200 nM
The estimate for compound 4 lay 1.2-fold (0.09 log units) below the measured number; low and high end bracket the measured number.
By their numbers in this assay, from the lowest: compounds 1, 4 and 3 (each within the scatter of the next). At a limit, above all of these: compound 2.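

In this assay, putting trifluoromethyl in place of hydroxy on this aromatic carbon gives a 1.4-fold lower number from compound 3 to compound 4 (0.15 log units; within the scatter), so the two compounds cannot be told apart. This is the first step shown that changes this place directly, and it shows that the hydrogen-bond donor and acceptor of hydroxy can go, in this pair, with no change beyond the scatter. Nothing shown here explains why the number holds.

Going by these compounds, whether an amine, a carboxylic acid or a longer chain on this carbon would move the number beyond the scatter remains open. Also open, on these data alone, is whether the same swap would read the same way elsewhere on this ring or on a molecule that differs from compound 3 in another place.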